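Aryl ester amides: cytotoxicity stays at the assay limit

A few compounds are considered here, and "the series" means these few. Any claim that something is new, unique, unknown or untested is made for them only; others in the source may bear on it.

Compound 1 `O=C(Oc1ccc(Cl)cc1C(=O)Nc1ccc(Cl)c(Cl)c1)c1ccc(Br)cc1` was tested in an ADME assay on HepG2 cells (Homo sapiens) for cytotoxicity, read by MTT assay, with a stated time of 72 h; on this read-out higher numbers stand for weaker inhibition and lower numbers for stronger inhibition. In this assay compound 1 gives > 50000 nM, which is a limit of the assay and not a number. Compound 2 `O=C(Oc1ccc(Br)cc1C(=O)Nc1ccc(C(F)(F)F)cc1)c1ccc([N+](=O)[O-])cc1` is likewise at a limit, giving > 50000 nM. Compound 3 `Cc1ccc(C(=O)Oc2ccc(Br)cc2C(=O)Nc2ccc(C(F)(F)F)cc2)cc1` also returns a limit, > 50000 nM. For the measured compounds named here, the single step between measured compounds, a step that the two limits leave unreadable from compound 2 to compound 3, cannot be read because both of its ends are limits; where every value stands is summed up by the limit of > 50000 nM in this assay, at which 3 of the 3 values shown sit.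

Compound 4 `O=C(Oc1ccc(Cl)cc1C(=O)Nc1ccc(C(F)(F)F)cc1)c1ccc(Br)cc1` differs from compound 1 by 4-(trifluoromethyl)phenyl in place of 3,4-dichlorophenyl on an amide-type nitrogen. Going by the values given here, no measured step covers this change; the only comparable swap, methyl in place of nitro, left the read-out at the limit. Because the limit of > 50000 nM in this assay, at which 3 of the 3 values shown sit, puts all three values at the limit, no step beyond the scatter is expected in this assay, and compound 4 is estimated to remain at that limit. Compound 4 is expected to give 60000 nM, within 30000 nM to 150000 nM. The step this estimate means is a step that the limit leaves unreadable from compound 1 to compound 4, an expected difference no larger than the scatter.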

Compound 4, half-maximal inhibitory concentration: > 50000 nM
Compound 4: only a limit was reported; the forecaster's own chance of this, stated with the estimate: 80%; the middle value is on the limit's open side.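

Compound 1 and compound 4 both return only a limit in this assay, so no step can be read between them. The compounds shown leave open how any structural change in the series moves the read-out, since every value stands at one limit: the limit of > 50000 nM in this assay, at which 4 of the 4 values shown sit.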